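Hydrogen in place of fluoro: notes on compound 2

A few compounds are considered here, and "the series" means these few. Any claim that something is new, unique, unknown or untested is made for them only; others in the source may bear on it.

Of the compounds shown here, two have numbers so far. In a functional assay on the whole organism (stomach) for inhibition, with Rattus norvegicus as the target (on this read-out lower numbers stand for an effect already at smaller amounts and higher numbers for an effect only at larger amounts of compound), compound 1 (`CC1(C)OC(/C=C/c2ccsc2)=CC1=O`) gives 16 mg/kg. Compound 2 (`CC1(C)OC(/C=C/c2ccc(F)cc2F)=CC1=O`) gives 100 mg/kg, the higher of the two numbers, and its gap to compound 1 lies beyond the scatter.

Compound 3 (`CC1(C)OC(/C=C/c2ccc(F)cc2)=CC1=O`) has yet to be measured in this assay. It differs from compound 2 by hydrogen in place of fluoro on an aromatic carbon, ortho to a large group and meta to a fluoro group. Going by the values given here, no measured pair isolates this change, so the step has no direct precedent.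

A moderate step towards a lower number is expected, slightly beyond the scatter, though a result within it would not surprise. The support is thin: compound 2 stands at 100 mg/kg, while compound 1, which carries no fluoro group, shows that the series can reach 16 mg/kg. The estimated change is a 2.5-fold lower number from compound 2 to compound 3 (0.40 log units; beyond the scatter). For compound 3 the expected value is 40 mg/kg, with an estimated range of 12 mg/kg to 120 mg/kg.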

Compound 3, dose for half-maximal effect: 50 mg/kg
For compound 3 the middle estimate is 1.3-fold (0.10 log units) below the measured one, within the range that was stated.
By their numbers in this assay, from the lowest: compound 1; then compounds 3 and 2 (each within the scatter of the next).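

Hydrogen in place of fluoro on an aromatic carbon, ortho to a large group and meta to a fluoro group, now has its first isolated pair in this assay (a 2.0-fold lower number from compound 2 to compound 3 (0.30 log units; within the scatter)). Going by these compounds alone, earlier, the only comparison available was between compounds that differ in more than one place, so this position could not be read on its own. With this single pair, the fluoro group at this carbon can be exchanged for hydrogen without a difference that stands clear of the usual scatter of the read-out, and no measurement here offers an explanation of this result.

The compounds shown leave open how this aromatic carbon responds to groups that differ more from fluoro and hydrogen, such as a methoxy group, an amine or a carboxylic acid. Within the data shown here, they also leave open what the remaining fluoro group contributes, since no pair isolates it, and compound 1 differs from compound 3 in more than one place and cannot settle this.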